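The source may hold more compounds than are shown below. What is called first, only, known or untested is meant among the compounds shown, and "the series" means these compounds.

In a functional assay on MCF7 cells (Homo sapiens) for cytotoxicity, read by CellTiter-Glo, with a stated time of 5 days (on this read-out higher numbers stand for weaker inhibition and lower numbers for stronger inhibition), compound 2 `CC/C(=C(/c1ccc(/C=C/C(=O)O)cc1)c1ccc2[nH]ncc2c1)c1ccccc1S(C)(=O)=O` gives 70 nM, the higher of two numbers, while compound 1 `CC/C(=C(/c1ccc(/C=C/C(=O)O)cc1)c1ccc2[nH]ncc2c1)c1ccccc1Cl` gives 2 nM. Compound 3 `CC/C(=C(/c1ccc(/C=C/C(=O)O)cc1)c1ccc2[nH]ncc2c1)c1cscc1C` differs from compound 2 by 4-methylthiophen-3-yl in place of 2-(methylsulfonyl)phenyl on a double-bonded chain carbon bound to a double-bonded chain carbon and a saturated chain carbon. Going by the values given here, the one measured step bearing on this, a 35-fold higher number from compound 1 to compound 2 (1.54 log units; beyond the scatter), is large and comes with methylsulfonyl in place of chloro on an aromatic carbon. Among the compounds with values here, compound 3 also lacks methylsulfonyl, so a large move to a lower number is expected, although no measured compound carries 4-methylthiophen-3-yl. The expected change is an 18-fold lower number from compound 2 to compound 3 (1.24 log units; beyond the scatter). Compound 3 is estimated at 4 nM, with a range from 1 nM to 20 nM.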

Compound 3, half-maximal inhibitory concentration: 2 nM
Compound 3: middle estimate off by 2.0-fold (0.30 log units), on the high side, within the range that was stated.
By their numbers in this assay, from the lowest: compounds 1 and 3 (each within the scatter of the next); then compound 2.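

In this assay, the place on a double-bonded chain carbon accepts a five-membered aromatic ring as well as a six-membered one: replacing 2-chlorophenyl with 4-methylthiophen-3-yl gives no change at the digits printed from compound 1 to compound 3 (within the scatter), while replacing 2-(methylsulfonyl)phenyl with it gives a 35-fold lower number from compound 2 to compound 3 (1.54 log units; beyond the scatter). Among these three, a low number therefore does not depend on a six-membered ring here, and only compound 2 stands apart. Nothing available accounts for either step. As far as these compounds go, whether a methoxy or an amine on the ring at this place would keep the number low remains open, as does the role of the methyl on the thiophene.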